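The compounds below may be only part of what the source reports. "The series", "measured", "known", "first", "only" and "open" are said of these compounds alone.

Compound 1 `N#Cc1ccc(O[C@H]2CN(S(=O)(=O)c3ccc(C(F)(F)F)cc3)C[C@@]2(O)CO)cc1F`: 5 ug/mL
Compound 2 `N#Cc1ccc(O[C@H]2CN(S(=O)(=O)c3ccc(C(F)(F)F)cc3C#N)C[C@@]2(O)CO)cc1F`: 25 ug/mL
Compound 3 `N#Cc1ccc(S(=O)(=O)[C@H]2CN(S(=O)(=O)c3ccc(Cl)cn3)C[C@@]2(O)CO)cc1`: > 1000 ug/mL, a limit of the assay and not a number

In a physicochemical assay for solubility, in simulated intestinal fluid, with a stated time of 4 h (a lower number here means a less soluble compound, a higher number a more soluble compound), compound 1 gives 5 ug/mL, the lower of the two exact numbers. Compound 4 `N#Cc1ccc(O[C@H]2CN(S(=O)(=O)c3ccc(Cl)cc3)C[C@@]2(O)CO)cc1F` changes one group of compound 1: chloro in place of trifluoromethyl on an aromatic carbon. Among the measured compounds shown here, no measured step makes this swap. For the measured compounds named here, the only measured step is a different change, cyano in place of hydrogen on an aromatic carbon, and it is modest: a 5.0-fold higher number from compound 1 to compound 2 (0.70 log units; beyond the scatter). Compound 3 also carries chloro, but it differs from compound 1 in several places, so it offers little guidance. A small upward move in this assay, possibly within the scatter, is therefore expected for compound 4: a 1.6-fold higher number from compound 1 to compound 4 (0.20 log units; within the scatter). For compound 4 the estimated value is 8 ug/mL, with an expected range from 3 ug/mL to 25 ug/mL.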

Compound 4, solubility: 44 ug/mL
Compound 4: middle estimate off by 5.5-fold (0.74 log units), on the low side; the measured number lies above the stated range.
By their numbers in this assay, from the lowest: compound 1; then compounds 2 and 4 (each within the scatter of the next). At a limit, above all of these: compound 3.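

In this assay, chloro in place of trifluoromethyl, on an aromatic carbon para to a large group, gives an 8.8-fold higher number from compound 1 to compound 4 (0.94 log units; beyond the scatter). The earlier step showed only a cyano group added to this ring, whereas this one shows that exchanging the group at this position also moves the number beyond the scatter. No measurement shown here explains that move. From the compounds shown here alone, whether an amine or a methoxy group at this position would give a similar number remains open. So does whether this swap gives a similar step on a different core.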